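Oxolan-3-yl replacing isopropyl at the amide carbonyl

The compounds below may be only part of what the source reports. "The series", "measured", "known", "first", "only" and "open" are said of these compounds alone.

Within the data shown here, compound 3 `Cc1cc(NC(=O)C(C)C)nn1Cc1cc(Cl)ccc1OCc1ccccc1` gives 25.1 nM in an assay on CHO-K1 cells for displacement of a labelled ligand from prostaglandin E2 receptor EP1 subtype (Homo sapiens) (on this read-out lower numbers stand for stronger inhibition and higher numbers for weaker inhibition), and stands second highest of the three numbers so far. Compound 2 `Cc1cc(C(=O)Nc2c(F)cccc2F)nn1Cc1cc(Cl)ccc1OCc1ccccc1` gives 10 nM in this assay, and compound 1 `Cc1cc(C(=O)Nc2cccc(F)c2)nn1Cc1cc(Cl)ccc1OCc1ccccc1` gives 200 nM. The steps of a 2.5-fold higher number from compound 2 to compound 3 (0.40 log units; beyond the scatter) and an 8.0-fold lower number from compound 1 to compound 3 (0.90 log units; beyond the scatter) both exchange the whole amide-bearing side of the core, as does a 20-fold lower number from compound 1 to compound 2 (1.30 log units; beyond the scatter). Compound 4 `Cc1cc(NC(=O)C2CCOC2)nn1Cc1cc(Cl)ccc1OCc1ccccc1` differs from compound 3 in oxolan-3-yl in place of isopropyl on a carbonyl carbon. Among the measured compounds shown here, no measured step alters the group on this carbonyl carbon alone, so none of the three steps sets the size of the change directly. Compound 4 is expected to move little, a step of a 1.2-fold higher number from compound 3 to compound 4 (0.08 log units; within the scatter) within the usual scatter. The estimate for compound 4 is 30 nM, ranging from 10 nM to 100 nM.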

Compound 4, half-maximal inhibitory concentration: 39.8 nM
The estimate for compound 4 lay 1.3-fold (0.12 log units) below the measured number, within the range that was stated.
By their numbers in this assay, from the lowest: compound 2; then compounds 3 and 4 (each within the scatter of the next); then compound 1.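

In this assay, among these compounds, the step of a 1.6-fold higher number from compound 3 to compound 4 (0.20 log units; within the scatter) is the first to alter the group on this carbonyl carbon alone, and it lies within the scatter, so oxolan-3-yl, with its ring and hydrogen-bond acceptor, reads as equivalent to isopropyl here. The wider exchanges, a 4.0-fold higher number from compound 2 to compound 4 (0.60 log units; beyond the scatter) and a 5.0-fold lower number from compound 1 to compound 4 (0.70 log units; beyond the scatter), place compound 4 on the same side of each of these two compounds as compound 3. No available evidence bears on the basis of this result.

Still open, as far as these compounds go, is how a longer chain, an amine or a carboxylic acid on this carbonyl carbon would read in this assay. From the compounds shown here alone, whether a larger ring such as oxan-4-yl would stay within the scatter of isopropyl also remains open.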